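Para Substituent Swap on the Benzylamine Arm

The source may hold more compounds than are shown below. What is called first, only, known or untested is meant among the compounds shown, and "the series" means these compounds.

The measured compounds are: compound 1 `O=S(=O)(NCCCNCc1ccc(C(F)(F)F)cc1)c1cc(C(F)(F)F)cc(C(F)(F)F)c1`, 2500 nM; compound 2 `CN(CCCNS(=O)(=O)c1cc(C(F)(F)F)cc(C(F)(F)F)c1)Cc1ccccc1`, 33000 nM; compound 3 `O=S(=O)(NCCCNCc1ccc(-c2ccccc2)cc1)c1cc(C(F)(F)F)cc(C(F)(F)F)c1`, 2400 nM, all in a functional assay on MIA PaCa-2 cells (Homo sapiens) for inhibition, read by MTT assay, with a stated time of 72 h; on this read-out higher numbers stand for weaker inhibition of growth and lower numbers for stronger inhibition of growth.

Compound 3 gives the lowest of the three numbers, but its value sits within the scatter of compound 1, so the two cannot be ordered; compound 2 is the only one set apart, lying well above both.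

Compound 4 `COc1ccc(CNCCCNS(=O)(=O)c2cc(C(F)(F)F)cc(C(F)(F)F)c2)cc1` differs from compound 3 by methoxy in place of phenyl on an aromatic carbon, the new group sitting on an aromatic carbon of a six-membered aromatic ring of carbon only, para to a large group. For the measured compounds named here, the one measured step that bears on this position is a 1.0-fold lower number from compound 1 to compound 3 (0.02 log units; within the scatter), where a group exchange at the same aromatic carbon left the number unchanged within the scatter. On that basis the methoxy exchange is expected to produce no step beyond the scatter in this assay, and the estimated step is a 1.3-fold higher number from compound 3 to compound 4 (0.10 log units; within the scatter). Compound 4 is therefore expected to give about 3000 nM, with a range from 1200 nM to 8000 nM.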

Compound 4, concentration for 50% growth inhibition: 2500 nM
The estimate for compound 4 lay 1.2-fold (0.08 log units) above the measured number, within the range that was stated.
By their numbers in this assay, from the lowest: compounds 3, 1 and 4 (each within the scatter of the next); then compound 2.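

In this assay, methoxy at this aromatic carbon, para to a large group, gives a 1.0-fold higher number from compound 3 to compound 4 (0.02 log units; within the scatter) and no change at the digits printed from compound 1 to compound 4 (within the scatter), so phenyl, trifluoromethyl and methoxy cannot be told apart here, although they differ in heavy atoms, ring and hydrogen-bond acceptors. For the compounds shown here, the only step beyond the scatter is a 13-fold lower number from compound 2 to compound 4 (1.12 log units; beyond the scatter), where (4-methoxybenzyl)amino replaces benzyl(methyl)amino, an exchange that alters the methyl and the methoxy together and so does not separate the two. No measurement is available to explain either the flat response at the aromatic carbon or the large step.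

Still open, going by these compounds, is whether a carboxylic acid or an amine at the same aromatic carbon would also leave the number unchanged. Also open, on these data alone, is how a longer chain would affect growth inhibition.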